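Sulfate on a Sugar Hydroxyl: Reading Potency from Limits

The compounds below may be only part of what the source reports. "The series", "measured", "known", "first", "only" and "open" are said of these compounds alone.

The compounds here were tested in a functional assay on A-375 cells (Homo sapiens), read by thymidine incorporation; on this read-out higher numbers stand for weaker inhibition and lower numbers for stronger inhibition. Compound 1, `C=CCCC(=O)N[C@H]1[C@@H](OCCc2ccccc2)O[C@H](CO)[C@@H](O)[C@@H]1O`, carries a free hydroxyl on its sugar core. In this assay compound 1 gives only a limit, > 50 uM. Compound 3, `C=CCCC(=O)N[C@H]1[C@@H](OCCc2ccccc2)O[C@H](CO)[C@@H](O)[C@@H]1OS(=O)(=O)O`, differs from compound 1 by sulfo in place of hydrogen on an oxygen on a saturated carbon. In this assay compound 3 likewise gives only a limit, > 50 uM. The step that the two limits leave unreadable from compound 1 to compound 3 is therefore not readable, since the limit of > 50 uM in this assay, at which 2 of the 3 values shown sit, hides whatever movement this change may have made.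

Compound 2, `CCCCCCCC/C=C\CCCCCCCCO[C@H]1O[C@H](CO)[C@@H](O)[C@H](O)[C@H]1NC(C)=O`, rests on a different core; how its core differs from that of compound 1 is not broken down here. In this assay, among the measured compounds shown here, compound 2 gives 4.8 uM, the only finite number among the three measured compounds.

Compound 4, `CCCCCCCC/C=C\CCCCCCCCO[C@H]1O[C@H](COS(=O)(=O)O)[C@@H](O)[C@H](O)[C@H]1NC(C)=O`, is not yet measured. It differs from compound 2 by sulfo in place of hydrogen on an oxygen on a saturated carbon. This is the same kind of change as from compound 1 to compound 3, though here the carbon bearing the oxygen has a saturated chain carbon as its other neighbour, whereas in compound 3 it has a saturated ring carbon.

The measured pair offers no readable size for this change, so the expectation for compound 4 leans on compound 2 alone. The step of a 1.3-fold higher number from compound 2 to compound 4 (0.10 log units; within the scatter) is expected to be small, with a wide margin of doubt in either direction. Compound 4 is estimated at 6 uM, plausibly between 1.5 uM and 30 uM.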

Compound 4, concentration for 50% inhibition: 0.6 uM
Estimate against measurement, compound 4: 10-fold (1.00 log units) above; the whole stated range lies above it.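

In this assay, placing sulfo in place of hydrogen on an oxygen on a saturated carbon gives an 8.0-fold lower number from compound 2 to compound 4 (0.90 log units; beyond the scatter), so on the core of compound 2 this change goes with stronger inhibition. The same kind of change cannot be sized on the core of compound 1, and the two steps cannot be compared, because compound 1 and compound 3 both stop at a limit: the limit of > 50 uM in this assay, at which 2 of the 4 values shown sit. The new step therefore shows that the change can matter on one core but not that its effect carries over to another, and the two sites also differ, since the carbon bearing the oxygen has a saturated chain carbon as its other neighbour in compound 4 and a saturated ring carbon in compound 3.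

The compounds shown leave open whether a different group on that same oxygen, such as a phosphate or a carboxylic acid, would match the step seen with sulfo. They also leave open whether a step of this size would survive on the core of compound 2 if a shorter chain replaced its long chain.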